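The compounds below may be only part of what the source reports. "The series", "measured", "known", "first", "only" and "open" are said of these compounds alone.

Of the compounds shown here, two from this series have been tested in a functional assay on MOLT-4 cells (Homo sapiens) for cytotoxicity, with a stated time of 72 h; a lower number here means a stronger inhibitor, a higher number a weaker inhibitor. Compound 1 `O=C1/C(=C/c2ccc(Cl)cc2)CCC/C1=C\c1ccc([N+](=O)[O-])cc1` gives 9120 nM. Compound 2 `COc1cc(/C=C2\CCC/C(=C\c3ccc([N+](=O)[O-])cc3)C2=O)cc(OC)c1OC` gives 6420 nM. These two numbers lie within the usual scatter of each other, so compound 1 cannot be separated from compound 2 on the evidence so far. Compound 3 `COc1ccc(/C=C2\CCC/C(=C\c3ccc([N+](=O)[O-])cc3)C2=O)cc1` has not yet been measured in this assay. It differs from compound 1 in one place: methoxy in place of chloro on an aromatic carbon. Among the compounds with values here, no measured pair shows this exact change, so there is no direct guide to its size. The step of a 1.2-fold lower number from compound 1 to compound 3 (0.08 log units; within the scatter) is expected to stay within the scatter, with no clear direction. On that basis compound 3 is estimated at 7500 nM, within a range from 3000 nM to 18000 nM.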

Compound 3, half-maximal inhibitory concentration: 300000 nM
For compound 3 the middle estimate is 40-fold (1.60 log units) below the measured one, outside the stated range (above it).
By their numbers in this assay, from the lowest: compounds 2 and 1 (each within the scatter of the next); then compound 3.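

In this assay the swap of chloro for methoxy on this aromatic carbon, para to a large group, turns out not to be a neutral exchange: the step is large (a 33-fold higher number from compound 1 to compound 3 (1.52 log units; beyond the scatter)) and lies well beyond the scatter. This position is therefore sensitive, since going from a chloro of one heavy atom to a methoxy of two is enough to leave a much weaker inhibitor. Nothing available here explains why this single change has so large an effect.

As far as these compounds go, with only these two groups compared at this position, it remains open whether a fluoro, a methyl or an amine there would give a number close to that of compound 1 or close to that of compound 3. This single pair also cannot show whether the same swap would have a similar effect on the other aromatic ring of the shared core.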